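From Bromo to Methyl at the Assay Limit

The compounds below may be only part of what the source reports. "The series", "measured", "known", "first", "only" and "open" are said of these compounds alone.

In an ADME assay on cells (Platelet, Homo sapiens) for inhibition, read by turbidimetry, with a stated time of 2 min (a higher number here means a weaker inhibitor, a lower number a stronger inhibitor), compound 1 `Cc1cc(C(=O)N/N=C/c2ccc([N+](=O)[O-])cc2)c2c(C)nn(-c3ccccc3)c2n1` gives > 100000 nM, and this result is a limit, not a number. Compound 2 `Cc1cc(C(=O)N/N=C/c2ccc(Br)cc2)c2c(C)nn(-c3ccccc3)c2n1` carries bromo in place of nitro on an aromatic carbon, and compound 2 also stands only at a limit, > 100000 nM. For the measured compounds named here, the only measured step is a step that the two limits leave unreadable from compound 1 to compound 2, with both results at the limit of > 100000 nM in this assay, at which 2 of the 2 values shown sit. Compound 3 `Cc1ccc(/C=N/NC(=O)c2cc(C)nc3c2c(C)nn3-c2ccccc2)cc1` has methyl in place of bromo on an aromatic carbon, para to a large group: methyl in place of bromo on an aromatic carbon. Going by the values given here, no measured step gives a size to carry over, so no firm size or direction is expected in this assay, and another limit is the likeliest result. The estimated step is a number no higher from compound 2 to compound 3 (the limit leaves the size open). For compound 3 the expected value is 100000 nM, with an estimated range from 40000 nM to 200000 nM.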

Compound 3, half-maximal inhibitory concentration: > 100000 nM
Compound 3 was reported as a limit (the forecaster's own chance of this, stated with the estimate: 70%); the middle value sits exactly at the limit.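

Compound 3, like compound 1 and compound 2, is reported only as a limit in this assay, so no step among the three can be read: the limit of > 100000 nM in this assay, at which 3 of the 3 values shown sit.

The compounds shown leave open how nitro, bromo and methyl compare, and whether any compound with the shared core gives a readable value.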